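A few compounds are considered here, and "the series" means these few. Any claim that something is new, unique, unknown or untested is made for them only; others in the source may bear on it.

Measured compounds:
compound 1, `Cc1ccc(-c2nc(CNc3ccc(C(=O)NO)cc3)n(-c3ccccc3)n2)o1`, 60.7%
compound 2, `CCc1ccc(-n2nc(-c3ccccc3)nc2CNc2ccc(C(=O)NO)cc2)cc1`, 38.3%
compound 3, `O=C(NO)c1ccc(NCc2nc(-c3ccc(Br)cc3)nn2-c2ccccc2)cc1`, 54.7%

In an assay on Sf9 cells for inhibition of protein deacetylase HDAC6 (Homo sapiens), read by fluorescence, with a stated time of 40 min, tested at 100 nM (on this read-out lower numbers stand for less inhibition and higher numbers for more inhibition at the one concentration tested (going by the name of the read-out)), compound 2 gives the lowest of the three numbers. Compound 3 stands nearer to it, and compound 1 is the furthest away; both of those gaps lie beyond the scatter, so the number for compound 2 is lower than that of either other compound on this read-out. Compound 4, `CC(C)c1ccc(-n2nc(-c3ccccc3)nc2CNc2ccc(C(=O)NO)cc2)cc1`, is not yet measured. It differs from compound 2 in one place: methyl in place of hydrogen on a saturated chain carbon bound to an aromatic carbon and a saturated chain carbon.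

Among the measured compounds shown here, only one measured step joins two compounds that differ in one place, a number 6 percentage points lower from compound 1 to compound 3 (within the scatter). That step changes the group on an aromatic carbon of the core, not the phenyl on the ring nitrogen, so it does not touch the position altered in compound 4. It shows that one exchange of a group at the edge of the core left the number within the scatter. For the measured compounds named here, no measured pair speaks to ethyl against isopropyl on the phenyl.

Given this, compound 4 is expected to stay close to compound 2 in this assay, with a number 0.3 percentage points lower from compound 2 to compound 4 (within the scatter) as the estimated step, which is within the scatter. Compound 4 is therefore estimated at 38%, with a range from 25% to 52%.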

Compound 4, a percentage reported as inhibition, at one concentration (the size of the read-out at that concentration, not a potency): 52.6%
Estimate against measurement, compound 4: 14.6 percentage points below; measured number above the stated range.
By their numbers in this assay, from the lowest: compound 2; then compounds 4, 3 and 1 (each within the scatter of the next).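

In this assay, exchanging 4-ethylphenyl for 4-isopropylphenyl gives a number 14.3 percentage points higher from compound 2 to compound 4 (beyond the scatter), so one added methyl, on a saturated chain carbon bound to an aromatic carbon and a saturated chain carbon, is enough to move the number beyond the usual scatter. Among the compounds shown here, the only earlier one-place comparison, a number 6 percentage points lower from compound 1 to compound 3 (within the scatter), concerned a different place and stayed within the scatter, so this pair is the first to show a single change altering the read-out by more than the scatter, and the first to show that the alkyl group on this phenyl matters in this assay. No available information bears on why the number rises with this methyl.

From the compounds shown here alone, what remains open is whether the trend from ethyl to isopropyl extends to a tert-butyl group or a cyclopropyl ring, or whether it holds for a longer chain such as n-butyl or for a methoxy group in the same place. The compounds shown also leave open whether the same exchange would raise the number on a core bearing 5-methylfuran-2-yl or 4-bromophenyl, as in compound 1 or compound 3.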